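The source may report more compounds than this note shows. Statements on the series, on what has been measured and on what is new or still open speak of the compounds shown alone.

Measured compounds:
compound 1 `CC(Nc1nc(N)nc2ccc(-c3cnn(C4CCNCC4)c3)cc12)c1c(Cl)ccc(F)c1Cl` gives 5100 nM in a functional assay on BT-474 cells (Homo sapiens) for antiproliferative activity, read by MTT assay, with a stated time of 72 h; on this read-out lower numbers stand for stronger inhibition and higher numbers for weaker inhibition;
compound 2 `CC(Nc1nc(N)nc2ccc(-c3cnn(C)c3)cc12)c1c(Cl)ccc(F)c1Cl` gives 7120 nM in this assay;
compound 3 `c1cnc2ccc(Nc3ncnc4ccc(-c5cnn(C6CCNCC6)c5)cc34)cc2c1` gives 12900 nM in this assay.

Compound 1 and compound 3 share no counted difference; the difference between the two cores is not broken down here. Compound 2 departs from compound 1 by methyl in place of piperidin-4-yl on an aromatic nitrogen, and this gave a 1.4-fold higher number from compound 1 to compound 2 (0.14 log units; within the scatter). Compound 4 `Cn1cc(-c2ccc3ncnc(Nc4ccc5ncccc5c4)c3c2)cn1`, not yet measured, departs from compound 3 by methyl in place of piperidin-4-yl on an aromatic nitrogen, the same change at the same place. Within the data shown here, the step is expected to be about as small here as it was there, because the only measured instance is a 1.4-fold higher number from compound 1 to compound 2 (0.14 log units; within the scatter), so a 1.4-fold higher number from compound 3 to compound 4 (0.14 log units; within the scatter) is the expected step from compound 3 to compound 4, carrying no weight beyond that single pair. Compound 4 is therefore estimated at 18000 nM in this assay, with an expected range from 8000 nM to 40000 nM.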

Compound 4, half-maximal inhibitory concentration: 10900 nM
Compound 4: the middle estimate sits 1.7-fold (0.22 log units) above what was measured; low and high end bracket the measured number.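

Replacing piperidin-4-yl with methyl on the aromatic nitrogen gives a 1.2-fold lower number from compound 3 to compound 4 (0.07 log units; within the scatter), so on this second core the step again stays within the scatter. Set side by side, the two instances in this assay do not differ: the same change on two cores in this assay, a 1.4-fold higher number (0.14 log units; within the scatter) from compound 1 to compound 2 and a 1.2-fold lower number (0.07 log units; within the scatter) from compound 3 to compound 4, 1.7-fold (0.22 log units) apart, within the scatter of two such steps. Among these compounds, this supports carrying the change between these two cores as a small step, but it rests on two pairs only, gives no direction for the step, and shows nothing about any other core.

Still open, as far as these compounds go, is whether another group on that nitrogen, such as a primary amine, a carboxylic acid or a longer chain, would move the number beyond the scatter. The differences between the two cores also remain unresolved, place by place.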